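From a Benzothiazole Thioether to a Pyrimidine Ether

The source may hold more compounds than are shown below. What is called first, only, known or untested is meant among the compounds shown, and "the series" means these compounds.

Compound 1, `CC(C)[C@H](NC(=O)COc1cccc2ccccc12)C(=O)N[C@@H](CC(=O)O)C(=O)CSc1ncc[nH]1`, in a functional assay on Jurkat cells (Homo sapiens) for inhibition (on this read-out higher numbers stand for weaker inhibition and lower numbers for stronger inhibition), reaches only the limit > 200000 nM.
Compound 2, `CC(C)[C@H](NC(=O)COc1cccc2ccccc12)C(=O)N[C@@H](CC(=O)O)C(=O)CSc1nc2ccccc2o1`, in this assay likewise reaches only the limit > 200000 nM.
Compound 3, `CC(C)[C@H](NC(=O)COc1cccc2ccccc12)C(=O)N[C@@H](CC(=O)O)C(=O)CSc1nc2ccccc2s1`, in this assay also reaches only the limit > 200000 nM.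

None of the three compounds gives a number: each stands at the same limit, (the limit of > 200000 nM in this assay, at which 3 of the 3 values shown sit). The steps a step that the two limits leave unreadable from compound 1 to compound 2, a step that the two limits leave unreadable from compound 1 to compound 3 and a step that the two limits leave unreadable from compound 2 to compound 3 cannot be read. Nothing is known about how the group on the sulfur shifts inhibition here. Compound 3 therefore stands at a limit and not at a measured value.

Compound 4, `CC(C)[C@H](NC(=O)COc1cccc2ccccc12)C(=O)N[C@@H](CC(=O)O)C(=O)COc1ccncn1`, differs from compound 3 by (pyrimidin-4-yl)oxy in place of (1,3-benzothiazol-2-yl)sulfanyl on a saturated chain carbon bound to a carbonyl carbon. For the measured compounds named here, no measured step bears directly on this change, since all three measured steps are unreadable. The only expectation that can be drawn is that compound 4 is estimated to stay near the limit as well, meaning a step of a number no higher from compound 3 to compound 4 (the limit leaves the size open) of no readable size. Compound 4 is thus expected to give about 200000 nM, within a range from 20000 nM to 1000000 nM.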

Compound 4, half-maximal inhibitory concentration: > 200000 nM
Compound 4 was reported as a limit; the forecaster's own chance of this, stated with the estimate: 70%; the middle value lies on the limit itself.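

Compound 4, like compound 1, compound 2 and compound 3, gives only a limit and no number in this assay, so none of the steps to compound 4 can be read: the limit of > 200000 nM in this assay, at which 4 of the 4 values shown sit.

The compounds shown leave open how strongly any of them inhibits, and whether changing the group on the saturated chain carbon bound to a carbonyl carbon shifts inhibition at all.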